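The source may hold more compounds than are shown below. What is called first, only, known or untested is meant among the compounds shown, and "the series" means these compounds.

Working notes on the series. All compounds share the core of compound 1 `O=C(Nc1ccc(Oc2ccnc3[nH]ccc23)cc1)c1cc(-c2ccc(C(F)(F)F)cc2)ccn1`, which in a functional assay on PC-3 cells (Homo sapiens) for cytotoxicity, read by MTT assay, with a stated time of 72 h (on this read-out lower numbers stand for stronger inhibition and higher numbers for weaker inhibition), gives 14200 nM. Compound 2 `O=C(Nc1ccc(Oc2ccnc3[nH]ccc23)c(F)c1)c1cc(-c2ccccc2)ccn1` carries one more fluoro on an aromatic carbon; its value of > 10000 nM is a limit of the assay and not a number, the single case covered by the limit of > 10000 nM in this assay, at which 1 of the 3 values shown sits. Compound 3 `O=C(Nc1ccc(Oc2ccnc3[nH]ccc23)c(F)c1)c1cc(-c2ccc(F)cc2)ccn1` carries 4-fluorophenyl and gives 710 nM, the lowest of the two numbers at hand, with compound 1 well separated from it. For the measured compounds named here, the one measured step, an at least 14-fold lower number from compound 2 to compound 3 (1.14 log units; beyond the scatter), is large and beyond the scatter, so the fluoro on the 4-fluorophenyl carbon moves the read-out strongly.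

Compound 4 `O=C(Nc1ccc(Oc2ccnc3[nH]ccc23)c(F)c1)c1cc(-c2ccc(C(F)(F)F)cc2)ccn1` differs from compound 3 by trifluoromethyl in place of fluoro on an aromatic carbon. Going by the values given here, no measured pair covers fluoro against trifluoromethyl at this place. Among the compounds with values here, the only trifluoromethyl compound, compound 1, lacks the fluoro on the amide-bearing ring and gives 14200 nM, a weak result. The swap from 4-fluorophenyl to 4-(trifluoromethyl)phenyl is therefore expected to cost potency: the step of a 4.9-fold higher number from compound 3 to compound 4 (0.69 log units; beyond the scatter) is estimated in the direction of a higher number, a clear loss though probably short of the weakness seen for compound 1. Compound 4 is accordingly expected to give 3500 nM, with a range from 900 nM to 14000 nM.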

Compound 4, half-maximal inhibitory concentration: 4350 nM
For compound 4 the middle estimate is 1.2-fold (0.09 log units) below the measured one; the range from low to high includes it.
By their numbers in this assay, from the lowest: compound 3; then compound 4; then compound 1.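

At this place, on an aromatic carbon para to a large group, this assay now allows fluoro and trifluoromethyl to be compared directly on one core: trifluoromethyl in place of fluoro gives a 6.1-fold higher number from compound 3 to compound 4 (0.79 log units; beyond the scatter) and so falls behind fluoro, yet trifluoromethyl in place of hydrogen still gives an at least 2.2-fold lower number from compound 2 to compound 4 (0.36 log units; beyond the scatter) as a gain. The value of compound 2 is a limit of the assay and not a number, so that second step fixes only a bound. The new compound also gives a second reading of fluoro in place of hydrogen, a 3.3-fold lower number from compound 1 to compound 4 (0.51 log units; beyond the scatter) on the core of compound 1, and the size of this change depends on where it is made: the same change on two cores in this assay, an at least 14-fold lower number (1.14 log units; beyond the scatter) from compound 2 to compound 3 and a 3.3-fold lower number (0.51 log units; beyond the scatter) from compound 1 to compound 4, at least 4.3-fold (0.63 log units) apart, beyond the scatter of two such steps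

Only hydrogen, fluoro and trifluoromethyl are shown at this place, so it stays open how a chloro, a methoxy, an amine or a carboxylic acid would compare with compound 3 at 710 nM in this series. Also open is whether fluoro stays ahead of trifluoromethyl on the core of compound 1, where only trifluoromethyl is shown at this place.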